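Ester in place of acid on the anilide ring

A few compounds are considered here, and "the series" means these few. Any claim that something is new, unique, unknown or untested is made for them only; others in the source may bear on it.

Compound 2 `NCc1ccc(C(=O)Nc2ccncc2F)cc1-c1cccc(C(=O)Nc2cccc(CC(=O)O)c2)c1` gives 1.5 nM in an assay on cells for inhibition of Rho-associated protein kinase 2 (Homo sapiens), read by radiometric assay and 33P incorporation, in the presence of a further agent that is not named here; a lower number here means a stronger inhibitor, a higher number a weaker inhibitor; compound 1 `CCCCOC(=O)c1cccc(NC(=O)c2cccc(-c3cc(C(=O)Nc4ccncc4F)ccc3CN)c2)c1` gives 27 nM.

Among the measured compounds shown here, compound 2 holds the lower of the two numbers in this assay, its only neighbour being compound 1, set apart by an 18-fold lower number from compound 1 to compound 2 (1.26 log units; beyond the scatter). Compound 3 `CCCOC(=O)c1ccc(NC(=O)c2cccc(-c3cc(C(=O)Nc4ccncc4F)ccc3CN)c2)cc1` differs from compound 2 by 4-(propoxycarbonyl)phenyl in place of 3-(carboxymethyl)phenyl on an amide-type nitrogen. For the measured compounds named here, the one measured step that bears on this, an 18-fold lower number from compound 1 to compound 2 (1.26 log units; beyond the scatter), runs the opposite way, from an ester to the acid, and was large. Compound 3 is therefore expected to give a higher number, by about a 17-fold higher number from compound 2 to compound 3 (1.22 log units; beyond the scatter), landing near compound 1. Compound 3 is estimated at 25 nM, within 8 nM to 80 nM.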

Compound 3, half-maximal inhibitory concentration: < 1 nM
Compound 3 was reported as a limit; the forecaster's own chance of this, stated with the estimate: 2%; middle value at least 25-fold (1.39 log units) away from the limit.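

In this assay compound 3 gives < 1 nM, which is a limit of the assay and not a number. The step, an at least 1.5-fold lower number from compound 2 to compound 3 (0.17 log units; that floor lies within the scatter), shows that a carboxylic acid is not required on the group at this amide-type nitrogen, and that an ester there need not carry a high number. Only its floor can be read: the limit of < 1 nM in this assay, at which 1 of the 3 values shown sits.

From the compounds shown here alone, whether the butoxycarbonyl and propoxycarbonyl chains or the place of the ester on the ring set compound 1 apart from compound 3 stays open. So does what an amine or a carboxylic acid would give in place of propoxycarbonyl.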